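From butylamino to pyrrolidin-1-yl: compound 3 to compound 4

A few compounds are considered here, and "the series" means these few. Any claim that something is new, unique, unknown or untested is made for them only; others in the source may bear on it.

Measured compounds and their values in a functional assay on HL-60 cells (Homo sapiens) for antiproliferative activity, read by MTT assay, with a stated time of 24 h; a lower number here means a stronger inhibitor, a higher number a weaker inhibitor
compound 1 `CCCCc1oc2ccccc2c1C(=O)c1ccc(OCC(=O)N2CCOCC2)cc1`: > 50000 nM
compound 2 `CCCCc1oc2ccccc2c1C(=O)c1ccc(OCC(=O)NCc2ccccc2)cc1`: > 50000 nM
compound 3 `CCCCNC(=O)CCCOc1ccc(C(=O)c2c(CCCC)oc3ccccc23)cc1`: > 50000 nM

Each of these entries is a limit and not a number. In this assay compound 3 gives > 50000 nM and this is a limit, so it has no rank within the series. The whole measured set reads the same way: the limit of > 50000 nM in this assay, at which 3 of the 3 values shown sit.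

The next compound is compound 4 `CCCCc1oc2ccccc2c1C(=O)c1ccc(OCCCC(=O)N2CCCC2)cc1`, and the change is pyrrolidin-1-yl in place of butylamino on a carbonyl carbon. No net charge comes or goes with it.

Going by the values given here, three measured steps bear on this change, and none gives a size: a step that the two limits leave unreadable from compound 1 to compound 2, a step that the two limits leave unreadable from compound 1 to compound 3 and a step that the two limits leave unreadable from compound 2 to compound 3. The first of these is also a swap on a carbonyl carbon. Compound 1, with morpholin-4-yl on a carbonyl carbon, has a ring there and still stands at the limit of > 50000 nM.

With only limits to go on, no step beyond the scatter is expected and no direction can be argued. The expected step is a number no higher from compound 3 to compound 4 (the limit leaves the size open). For compound 4 the estimate is 50000 nM, with an expected range from 20000 nM to 100000 nM, and another report as a limit is the likeliest outcome.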

Compound 4, half-maximal inhibitory concentration: 29900 nM
Compound 4: the middle estimate sits 1.7-fold (0.22 log units) above what was measured, within the range that was stated.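

In this assay compound 4 gives 29900 nM, the first entry in the series that is a number and not a limit, and it comes with pyrrolidin-1-yl on the carbonyl carbon, where the count of hydrogen-bond donors in that group goes from 1 in butylamino to 0. The swap itself reads as an at least 1.6-fold lower number from compound 3 to compound 4 (0.22 log units; that floor lies within the scatter), and the two wider changes read as an at least 1.6-fold lower number from compound 2 to compound 4 (0.22 log units; that floor lies within the scatter) and an at least 1.6-fold lower number from compound 1 to compound 4 (0.22 log units; that floor lies within the scatter); each is only a floor, and each floor lies within the scatter, so the true size of these steps stays open and none is shown to exceed the scatter. The rest of the set remains at one limit: the limit of > 50000 nM in this assay, at which 3 of the 4 values shown sit.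

The compounds shown do not separate the pyrrolidin-1-yl ring from the loss of the amide hydrogen, a question that diethylamino or piperidin-1-yl on the same carbonyl carbon would address. They also leave open whether the result holds for pyrrolidin-1-yl on the shorter chain carried by compound 1 and compound 2, or for a longer chain between the ring oxygen and the carbonyl.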